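A few compounds are considered here, and "the series" means these few. Any claim that something is new, unique, unknown or untested is made for them only; others in the source may bear on it.

Measured compounds in a physicochemical assay for lipophilicity, using the shake flask method, in phosphate buffer, measured as octanol-water partition, with a stated time of 30 min, at pH 7.4; on this read-out lower numbers stand for lower lipophilicity and higher numbers for higher lipophilicity:
- compound 1, `Cn1cc(-c2cnc(NCc3c(F)ccc4c3CCO4)c3cn[nH]c(=O)c23)cn1`: 2.7
- compound 2, `COCCC(=O)Nc1cnc(NCc2c(F)ccc3c2CCO3)n2cnnc12`: 1.4

Compound 1 holds the higher of the two numbers in this assay. Going by the values given here, the nearest measured neighbour, compound 2, gives 1.4, a gap beyond the usual scatter; the two compounds differ in several places at once, so no single step is recorded between them, and the pair says only that the series already spans a substantial range in this assay.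

Compound 3, `Cc1nc(CN(C)C)ccc1-c1cnc(NCc2c(F)ccc3c2CCO3)c2cn[nH]c(=O)c12`, has not yet been measured. It is built from compound 1 by one change: 6-((dimethylamino)methyl)-2-methylpyridin-3-yl in place of 1-methyl-1H-pyrazol-4-yl on an aromatic carbon

Among the compounds with values here, no measured pair maps this change, so the expectation rests on the structural difference alone. The step from compound 1 to compound 3 is estimated as a number 0.80 log units lower from compound 1 to compound 3 (beyond the scatter), a move downward that is expected to exceed the scatter but to stay well short of the gap seen between compound 1 and compound 2. On that basis compound 3 is estimated to give 1.9 in this assay, with a plausible range from 1.2 to 2.6.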

Compound 3, distribution coefficient: 2
The estimate for compound 3 lay 0.10 log units below the measured number; the range from low to high includes it.
By their numbers in this assay, from the lowest: compound 2; then compound 3; then compound 1.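

This position, an aromatic carbon of a six-membered aromatic ring with 1 nitrogen in the core of compound 1, now has one single-place step in this assay: 6-((dimethylamino)methyl)-2-methylpyridin-3-yl in place of 1-methyl-1H-pyrazol-4-yl gives a number 0.70 log units lower from compound 1 to compound 3 (beyond the scatter). The entering group has 11 heavy atoms against 6 for the leaving group, with the same counts of hydrogen-bond donors and acceptors, so in this one step the larger group goes with the lower number, and heavy atom count alone does not set the direction of change at this position. No supporting measurement bears on the reason for this step.

As far as these compounds go, the methyl group, the dimethylamino group and the pyridine ring enter together, so the share of the step belonging to each remains open. Also open, from the compounds shown here alone, is whether a morpholine or a carboxylic acid in place of the dimethylamino group would move the number in the same direction at this position, and whether the step would carry over to the core of compound 2.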